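This account rests on a few compounds, and the source may have more. Where it says the series, first, only, none or still open, it means among the compounds named here.

Measured so far in an assay on isolated protein for inhibition of protein deacetylase HDAC6 (Homo sapiens), read by fluorescence; on this read-out lower numbers stand for stronger inhibition and higher numbers for weaker inhibition:
compound 1 `Cn1cc(-c2cc(C(C)(C)O)ccc2OC2CC2)c2cc(C(=O)NCCCCCCC(=O)NO)[nH]c2c1=O`: 5.5 nM
compound 2 `Cn1cc(-c2ccccc2Oc2ccccc2)c2cc(C(=O)NCCCC(=O)NO)[nH]c2c1=O`: 144 nM
compound 3 `CC(C)Oc1ccc(C(C)(C)O)cc1-c1cn(C)c(=O)c2[nH]c(C(=O)NCc3ccc(C(=O)NO)cc3)cc12`: 52 nM

Compound 2 stands at the highest number of the three. Its nearest neighbour is compound 3, and that gap is already beyond the scatter; compound 1 lies furthest away, again beyond the scatter. For the measured compounds named here, the three compounds differ from one another in more than one place, so no single counted step links them, and the comparison says only what the three values show.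

Compound 4 `Cn1cc(-c2ccccc2Oc2ccccc2)c2cc(C(=O)NCCCCCCC(=O)NO)[nH]c2c1=O` is yet to be measured. It differs from compound 2 in one place: 3-(hydroxycarbamoyl)propyl in place of hydroxycarbamoyl on a saturated chain carbon, three bonds along the chain from an amide-type nitrogen. The rest of compound 2 is kept unchanged; only the chain from the amide-type nitrogen to the hydroxycarbamoyl end grows.

A gain is expected because compound 1 gives 5.5 nM with the same long chain to the hydroxycarbamoyl group, though the rest of compound 1 differs too. The step of a 7.2-fold lower number from compound 2 to compound 4 (0.86 log units; beyond the scatter) is therefore expected to lie beyond the scatter, toward stronger inhibition. Compound 4 is estimated at 20 nM, with a range from 6 nM to 70 nM.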

Compound 4, half-maximal inhibitory concentration: 4.7 nM
For compound 4 the middle estimate is 4.3-fold (0.63 log units) above the measured one; measured number below the stated range.
By their numbers in this assay, from the lowest: compounds 4 and 1 (each within the scatter of the next); then compound 3; then compound 2.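

In this assay, for the compounds shown here, extending the chain from the amide-type nitrogen to the hydroxycarbamoyl end gives a 31-fold lower number from compound 2 to compound 4 (1.49 log units; beyond the scatter) as the first single-change step, and it is large. Going by these compounds alone, the rest of compound 2 is kept unchanged, so this difference belongs to the change from 3-(hydroxycarbamoyl)propyl to 6-(hydroxycarbamoyl)hexyl, a link the earlier compounds, which differ in more than one place, could not make. No measurement on hand explains the gain.

The compounds shown leave open how the value changes with chain length, at intermediate chains such as 4-(hydroxycarbamoyl)butyl or with a longer chain such as 7-(hydroxycarbamoyl)heptyl. Also open, as far as these compounds go, is whether a carboxylic acid could stand in place of the hydroxycarbamoyl end on the longer chain.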